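The source may hold more compounds than are shown below. What is called first, only, known or untested is meant among the compounds shown, and "the series" means these compounds.

Working notes on the series. Of the compounds shown here, three have been measured in an assay on HEK293F cells for inhibition of cholesterol 24-hydroxylase (Homo sapiens), read by trypan blue exclusion, with stated times of 15 min and 5 h; on this read-out lower numbers stand for stronger inhibition and higher numbers for weaker inhibition. Compound 1 `O=C(NC1CC1)N1CCC(c2cnccc2-c2ccccc2)CC1` gives 950 nM in this assay. Compound 2 `O=C(NC1CC1)C1CCN(c2cnccc2-c2ccccn2)CC1` gives 160 nM in this assay. Compound 3 `CCNC(=O)C1CCN(c2cncnc2-c2ccccc2)CC1` gives 58 nM in this assay. Compound 3 stands at the lowest number of the three: compound 2 sits nearest, with a higher number that lies beyond the scatter, and compound 1 stands furthest, with a higher number well beyond the scatter. Within the data shown here, the measured compounds differ from one another in several places at once, so no single structural step between them can be read off from their values.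

Compound 4 `CCN(C)C(=O)C1CCN(c2cncnc2-c2ccccc2)CC1` is not yet measured in this assay. It differs from compound 3 in one place, (methyl in place of hydrogen on an amide-type nitrogen), that is, methyl in place of hydrogen on an amide-type nitrogen. Among the measured compounds shown here, no pair among the measured compounds shows this change, so its size in this assay is not known from the series. For compound 4 a modest move toward a higher number in this assay is expected, with the expected step being a 2.1-fold higher number from compound 3 to compound 4 (0.32 log units; beyond the scatter). The estimated value for compound 4 in this assay is 120 nM, with a range from 40 nM to 400 nM.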

Compound 4, half-maximal inhibitory concentration: 14 nM
For compound 4 the middle estimate is 8.6-fold (0.93 log units) above the measured one, and the stated range ends above it.
By their numbers in this assay, from the lowest: compound 4; then compound 3; then compound 2; then compound 1.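

Methyl in place of hydrogen on the amide-type nitrogen gives a 4.1-fold lower number from compound 3 to compound 4 (0.62 log units; beyond the scatter) in this assay and is the first single-place step that can be read in the series. It shows that, with the rest of compound 3 unchanged, the amide hydrogen is not needed for a low number at this position, and that one added carbon on this nitrogen lowers the number rather than raising it. The series offers no measurement that explains why this methyl lowers the number.

The compounds shown test only methyl at this place, so it remains open whether a larger group on this nitrogen, such as a second ethyl, a longer propyl chain or a pyrrolidine ring closed through the nitrogen, would lower the number further or reverse the step. As far as these compounds go, it also remains open whether the same methyl would give a step of similar size on the cyclopropyl-bearing amide nitrogen of compound 2, whose core differs from that of compound 3.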